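Removing a methoxy from the fused ring of compound 3

The source may report more compounds than this note shows. Statements on the series, on what has been measured and on what is new or still open speak of the compounds shown alone.

Measured so far:
- compound 1, `COc1ccc(-c2[nH]c3ccccc3c2/C=C(\C#N)S(=O)(=O)c2ccccc2)cc1`: 4800 nM
- compound 2, `CC(=O)/C(=C\c1c(-c2ccccc2)[nH]c2ccccc12)S(=O)(=O)c1ccccc1`: 3800 nM
- compound 3, `COc1ccc2[nH]c(-c3ccccc3)c(/C=C(\C#N)S(=O)(=O)c3ccccc3)c2c1`: 17500 nM

All three compounds were tested in a functional assay on TK-10 cells (Homo sapiens) for inhibition, read by sulforhodamine B assay, with a stated time of 48 h; a higher number here means a weaker inhibitor of growth, a lower number a stronger inhibitor of growth. Compound 3 stands at the highest of the three numbers. In this assay compound 1 gives 4800 nM, and compound 2 gives 3800 nM; both numbers lie well below that of compound 3, each beyond the usual scatter of this kind of measurement. Compound 1 carries its methoxy on the detached six-membered ring rather than on the fused system, and compound 2 carries no methoxy at all.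

Compound 4, `N#C/C(=C\c1c(-c2ccccc2)[nH]c2ccccc12)S(=O)(=O)c1ccccc1`, has not yet been measured. It differs from compound 3 in one place: hydrogen in place of methoxy on an aromatic carbon. With the methoxy gone from the fused system, compound 4 resembles compound 2 in its core substitution pattern, and compound 1 in its nitrile group. Since compound 1 gives 4800 nM and compound 2 gives 3800 nM, both lower than compound 3, the step is expected to be downward, beyond the scatter, as estimated in a 3.2-fold lower number from compound 3 to compound 4 (0.50 log units; beyond the scatter). Compound 4 is therefore estimated at 5500 nM, within a range of 2000 nM to 15000 nM.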

Compound 4, concentration for 50% growth inhibition: 5600 nM
Estimate against measurement, compound 4: 1.0-fold (0.01 log units) below, and the stated range covers the measured number.
By their numbers in this assay, from the lowest: compounds 2, 1 and 4 (each within the scatter of the next); then compound 3.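

In this assay, the methoxy on the fused ring system proves to matter: replacing it with hydrogen gives a modest step beyond the scatter (a 3.1-fold lower number from compound 3 to compound 4 (0.49 log units; beyond the scatter)). The same exchange on the detached ring of compound 1 stays within the scatter (a 1.2-fold higher number from compound 1 to compound 4 (0.07 log units; within the scatter)), so among these compounds the effect of removing a methoxy differs with the ring that carries it, and cyano in place of acetyl also stays within the scatter (a 1.5-fold higher number from compound 2 to compound 4 (0.17 log units; within the scatter)). Nothing available explains this difference between the two methoxy placements.

Going by these compounds, whether an ethoxy or an amine on this aromatic carbon would give a similar number remains open. On these data alone, it is also open whether the methoxy on the fused ring system would give a similar step in a compound carrying acetyl instead of nitrile.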